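Hydroxy for Methoxy on the Side Chain

The compounds below may be only part of what the source reports. "The series", "measured", "known", "first", "only" and "open" are said of these compounds alone.

Measured so far:
Compound 1, `C/C=C/c1cc(C)cc(N)n1`: 282 nM
Compound 2, `COC(C)Cc1cc(C)cc(N)n1`: > 5000 nM

Both compounds were tested in an assay on isolated protein for inhibition of Nitric oxide synthase, inducible (Homo sapiens), with a stated time of 30 min; on this read-out lower numbers stand for stronger inhibition and higher numbers for weaker inhibition. Compound 1 gives 282 nM. For compound 2 the assay reports only a limit, > 5000 nM, and not a number. Compound 2 stands at the limit of > 5000 nM in this assay, at which 1 of the 2 values shown sits.

Compound 3, `Cc1cc(N)nc(CC(C)O)c1`, has not yet been measured. It differs from compound 2 by hydrogen in place of methyl on an oxygen on a saturated carbon. Going by the values given here, no pair of measured compounds shows what this kind of exchange does in this assay, so the expected step from compound 2 to compound 3 is uncertain; it is expected to be small, a number no higher from compound 2 to compound 3 (the limit leaves the size open), and may not exceed the usual scatter. Compound 3 is therefore expected to remain weak, with an estimated 5000 nM and a range from 1000 nM to 25000 nM, with a fair chance that the assay again reports only a limit.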

Compound 3, half-maximal inhibitory concentration: 1780 nM
Compound 3: the middle estimate sits 2.8-fold (0.45 log units) above what was measured, within the range that was stated.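

In this assay, exchanging methoxy for hydroxy on the side chain gives an at least 2.8-fold lower number from compound 2 to compound 3 (0.44 log units; beyond the scatter), so the group on this oxygen does matter for the read-out. Compound 2 supplies only a limit, so this step has a bound and no exact size: the limit of > 5000 nM in this assay, at which 1 of the 3 values shown sits. The hydroxy side chain still falls short of the unsaturated one, since 2-hydroxypropyl in place of prop-1-en-1-yl gives a 6.3-fold higher number from compound 1 to compound 3 (0.80 log units; beyond the scatter).

That last step changes both the saturation of the chain and the presence of the oxygen at once, so a plain propyl chain would be needed to tell the two apart. On these data alone, whether an amine in place of the hydroxy, or a longer chain carrying it, would give a lower number also stays open.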